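Swapping thiophene for benzofuran on a methyl nucleoside

This account rests on a few compounds, and the source may have more. Where it says the series, first, only, none or still open, it means among the compounds named here.

Measured in a functional assay on CEM-DNR-bulk cells (Homo sapiens), read by MTT assay, with a stated time of 72 h; a higher number here means a weaker inhibitor, a lower number a stronger inhibitor:
Compound 1 `COc1ncnc2c1c(-c1cc3ccccc3o1)cn2[C@@H]1O[C@H](CO)[C@@H](O)[C@H]1O`: 10800 nM
Compound 2 `CN(C)c1ncnc2c1c(-c1cc3ccccc3o1)cn2[C@@H]1O[C@H](CO)[C@@H](O)[C@H]1O`: > 20000 nM, a limit of the assay and not a number
Compound 3 `Cc1ncnc2c1c(-c1ccsc1)cn2[C@@H]1O[C@H](CO)[C@@H](O)[C@H]1O`: 8560 nM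

Compound 3, at 8560 nM, lies within the scatter of compound 1, at 10800 nM. Compound 4 `Cc1ncnc2c1c(-c1cc3ccccc3o1)cn2[C@@H]1O[C@H](CO)[C@@H](O)[C@H]1O` differs from compound 3 by one change, (1-benzofuran-2-yl in place of thiophen-3-yl on an aromatic carbon). Within the data shown here, only one measured step bears on it, an at least 1.8-fold higher number from compound 1 to compound 2 (0.26 log units; that floor lies within the scatter), and that step concerns dimethylamino and methoxy, not the group exchanged here. Compound 1, at 10800 nM, already carries 1-benzofuran-2-yl, so no step beyond the scatter is expected in this assay. The expected change is a 1.2-fold higher number from compound 3 to compound 4 (0.07 log units; within the scatter). For compound 4 the estimate is 10000 nM, with an expected range of 3500 nM to 20000 nM.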

Compound 4, half-maximal inhibitory concentration: > 20000 nM
Compound 4: only a limit was reported; the forecaster's own chance of this, stated with the estimate: 20%; middle value at least 2.0-fold (0.30 log units) away from the limit.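

In this assay, 1-benzofuran-2-yl in place of thiophen-3-yl on an aromatic carbon gives an at least 2.3-fold higher number from compound 3 to compound 4 (0.36 log units; beyond the scatter), the first step shown at this position and the first here that is beyond the scatter. At the other varied place, methyl in place of methoxy gives an at least 1.8-fold higher number from compound 1 to compound 4 (0.26 log units; that floor lies within the scatter). The value of compound 4 is a limit of the assay and not a number, and the step between compound 2 and compound 4 cannot be read: the limit of > 20000 nM in this assay, at which 2 of the 4 values shown sit.

Going by these compounds, whether thiophen-3-yl would keep its edge over 1-benzofuran-2-yl with methoxy on the shared core stays open. So does how a furan-2-yl group or a plain phenyl ring would stand at this position, or an amine in place of methyl.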